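Oxime ether variation on an aminopyrimidine antiproliferative series

This account rests on a few compounds, and the source may have more. Where it says the series, first, only, none or still open, it means among the compounds named here.

Measured so far:
compound 1 `CO/N=C/c1c(N)ncnc1Oc1ccc2cccnc2c1` — 1820 nM
compound 2 `COCCO/N=C/c1c(N)ncnc1Oc1ccc2[nH]c(C)cc2c1F` — 308 nM
compound 3 `CO/N=C/c1c(N)ncnc1Oc1ccc2[nH]cc(C)c2c1` — 306 nM

In a functional assay on HeLa cells (Homo sapiens) for antiproliferative activity (a higher number here means a weaker inhibitor, a lower number a stronger inhibitor), compound 2 gives 308 nM, the second highest of the three numbers. Compound 3 sits within the scatter of compound 2, so the two cannot be ordered. Compound 1 lies beyond the scatter of compound 2, with a higher number.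

Compound 4 `Cc1cc2c(F)c(Oc3ncnc(N)c3/C=N/OCc3ccccc3)ccc2[nH]1` has not yet been measured in this assay. Its difference from compound 2 is phenyl in place of methoxymethyl on a saturated chain carbon bound to an oxygen on an unsaturated carbon. Within the data shown here, no pair of measured compounds spans a single change of this kind, so the step from compound 2 to compound 4 has no precedent here. A modest step is expected, with the estimate a 1.3-fold lower number from compound 2 to compound 4 (0.13 log units; within the scatter) leaning toward a lower number. Compound 4 is estimated at 230 nM, in the range 70 nM to 800 nM.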

Compound 4, half-maximal inhibitory concentration: 266 nM
Compound 4: middle estimate off by 1.2-fold (0.06 log units), on the low side; measured number inside the range.
By their numbers in this assay, from the lowest: compounds 4, 3 and 2 (each within the scatter of the next); then compound 1.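

In this assay, phenyl in place of methoxymethyl on a saturated chain carbon bound to an oxygen on an unsaturated carbon gives a 1.2-fold lower number from compound 2 to compound 4 (0.06 log units; within the scatter), so this change leaves the number unresolved from that of compound 2. The entering group has more heavy atoms, an aromatic ring and no hydrogen-bond acceptor, yet none of these differences produces a step beyond the scatter. Nothing available explains this result.

The compounds shown leave open whether an amine, a carboxylic acid or a longer chain here would move the number beyond the scatter. They also leave open how a substituted phenyl would read.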